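Swapping methoxy for ethyl on a pyrimidine-like core and stability

The compounds below may be only part of what the source reports. "The series", "measured", "known", "first", "only" and "open" are said of these compounds alone.

Of the compounds shown here, three have been measured in an in vitro ADME assay on microsomes (Rattus norvegicus) for metabolic stability; a lower number here means that the compound disappears faster, a higher number that the compound lasts longer. Compound 2 `CCc1nc(-c2ccc(OC(F)(F)F)cc2OC)c(OC)nc1NC(CC)CC` gives 0.6 h in this assay. Compound 1 `CCc1nc(-c2ccc(OC(F)(F)F)cc2OC)c(CC)nc1NC(CC)CC` differs from it by one change, (ethyl in place of methoxy on an aromatic carbon), and in this assay compound 1 gives 0.0417 h; the step of a 14-fold lower number from compound 2 to compound 1 (1.16 log units; beyond the scatter) is a large one. Compound 3 `CCC(CC)Nc1nc(OC)c(-c2ccc(Cl)cc2Cl)nc1OC` carries a different aromatic group on its core, and the difference between the two cores is not broken down here. In this assay compound 3 gives 0.0417 h, which is level with compound 1 at the digits printed; both sit well beneath compound 2.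

Compound 4 `CCc1nc(-c2ccc(Cl)cc2Cl)c(OC)nc1NC(CC)CC` is not yet measured. It arises from compound 3 by ethyl in place of methoxy on an aromatic carbon. This is the same kind of change that led from compound 2 to compound 1, but not the same: in compound 1 the new ethyl sits ortho to a large group, meta to a (pentan-3-yl)amino group and para to an ethyl group, whereas in compound 4 it sits ortho to a (pentan-3-yl)amino group, meta to a 2,4-dichlorophenyl group and para to a methoxy group. Among the compounds with values here, only one earlier example of this change exists, so the expectation rests on it alone. Because compound 2 to compound 1 showed a 14-fold lower number from compound 2 to compound 1 (1.16 log units; beyond the scatter), a lower number is expected for compound 4 than for compound 3, with the step estimated as a 2.1-fold lower number from compound 3 to compound 4 (0.32 log units; beyond the scatter). Compound 3 already starts at a very low number, so the estimate for compound 4 is 0.02 h, expected between 0.004 h and 0.06 h.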

Compound 4, half-life: 0.183 h
Beside the measured number, compound 4's estimate is 9.2-fold (0.96 log units) below it, outside the stated range (above it).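

In this assay, putting ethyl in place of methoxy gives a 4.4-fold higher number from compound 3 to compound 4 (0.64 log units; beyond the scatter), a modest step in the direction opposite to the one seen earlier. Set beside that earlier step, the result shows that this change does not carry over from one core to the other, neither in direction nor in size: the same change on two cores in this assay, a 14-fold lower number (1.16 log units; beyond the scatter) from compound 2 to compound 1 and a 4.4-fold higher number (0.64 log units; beyond the scatter) from compound 3 to compound 4, 63-fold (1.80 log units) apart, beyond the scatter of two such steps

What it does not show is the reason, since the two pairs differ both in their aromatic group and in where the swap takes place, with the new ethyl in compound 4 sitting ortho to a (pentan-3-yl)amino group; two pairs cannot separate these differences, and they say nothing about how the change would behave on any further core.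

Open questions remain about the groups at the place that was changed, for instance whether a propyl chain or a dimethylamino group there would follow compound 3 or compound 4. Going by these compounds, it also remains open whether a compound with the 2,4-dichlorophenyl group and ethyl at both places on the core, as in compound 1, would show the drop seen with compound 1 or hold the gain seen with compound 4.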